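The compounds below may be only part of what the source reports. "The series", "measured", "known", "first", "only" and "open" are said of these compounds alone.

Compound 1 `Nc1ccccc1NC(=O)CCCCCN(CC(=O)NC1CCCCC1)C(=O)c1ccccc1`, compound 2 `Nc1ccccc1NC(=O)CCCCCN(CC(=O)NCc1ccccc1)C(=O)c1cccc2ccccc12` and compound 3 `Cc1ccc(CNC(=O)CN(CCCCCC(=O)Nc2ccccc2N)C(=O)c2cc(C)cc(C)c2)cc1` share a core and were tested in a functional assay on CAL-27 cells (Homo sapiens) for cytotoxicity, read by MTT assay, with a stated time of 72 h; on this read-out higher numbers stand for weaker inhibition and lower numbers for stronger inhibition. In this assay compound 1 gives 30900 nM, the highest of the three numbers; compound 3 gives 18200 nM, a gap from compound 1 that lies within the scatter, while compound 2 gives 11000 nM, a gap that lies beyond it. Compound 4 `Cc1cc(C)cc(C(=O)N(CCCCCC(=O)Nc2ccccc2N)CC(=O)NC2CCCCC2)c1` has not yet been measured. It differs from compound 1 in one place: 3,5-dimethylphenyl in place of phenyl on a carbonyl carbon. Among the compounds with values here, no step between measured compounds isolates this change, so the expected step from compound 1 to compound 4 in this assay, a 1.5-fold lower number from compound 1 to compound 4 (0.19 log units; within the scatter), is small and toward a lower number, likely inside the scatter. Compound 4 is expected to give about 20000 nM, between 8000 nM and 50000 nM.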

Compound 4, half-maximal inhibitory concentration: 17500 nM
Estimate against measurement, compound 4: 1.1-fold (0.06 log units) above; low and high end bracket the measured number.
By their numbers in this assay, from the lowest: compounds 2, 4, 3 and 1 (each within the scatter of the next, the first and the last beyond it).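

In this assay, 3,5-dimethylphenyl in place of phenyl on a carbonyl carbon gives a 1.8-fold lower number from compound 1 to compound 4 (0.25 log units; within the scatter) and so does not separate the two groups at this position. With 3,5-dimethylphenyl held, cyclohexyl in place of 4-methylbenzyl on an amide-type nitrogen gives a 1.0-fold lower number from compound 3 to compound 4 (0.02 log units; within the scatter) and likewise does not separate those two groups. No measurement shown gives a reason for either step. The compounds shown leave open whether an amine or a carboxylic acid in place of the methyl groups of 3,5-dimethylphenyl would move the number beyond the scatter.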